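A few compounds are considered here, and "the series" means these few. Any claim that something is new, unique, unknown or untested is made for them only; others in the source may bear on it.

In a functional assay on SK-BR-3 cells (Homo sapiens) for antiproliferative activity (a lower number here means a stronger inhibitor, a higher number a weaker inhibitor), compound 1 (`CC(C)=CCc1cc(C(=O)Nc2cc3ccc(OCC4CCN(C)C4)c(C)c3oc2=O)ccc1O`) gives 920 nM and compound 2 (`CC(C)=CCc1cc(C(=O)Nc2cc3ccc(OCCCNCC(=O)O)c(C)c3oc2=O)ccc1O`) gives 7570 nM. Compound 3 (`CC(C)=CCc1cc(C(=O)Nc2cc3ccc(OCCCN(C)C4CCCCC4)c(C)c3oc2=O)ccc1O`) gives 970 nM, level with compound 1 and well apart from compound 2, the measured steps being a 1.1-fold higher number from compound 1 to compound 3 (0.02 log units; within the scatter) and a 7.8-fold lower number from compound 2 to compound 3 (0.89 log units; beyond the scatter). Compound 4 (`CC(C)=CCc1cc(C(=O)Nc2cc3ccc(OCCCN[C@H](C)c4ccccc4)c(C)c3oc2=O)ccc1O`) changes the end of the same chain: (1-phenylethyl)amino in place of cyclohexyl(methyl)amino on a saturated chain carbon, three bonds along the chain from an oxygen on an aromatic ring. Among the measured compounds, only the (carboxymethyl)amino group of compound 2 has shifted the number, with an 8.2-fold higher number from compound 1 to compound 2 (0.92 log units; beyond the scatter). For the measured compounds named here, no measured compound carries an aromatic ring at this place, so the guide is limited, and no step beyond the scatter is expected in this assay. The estimated step is a 1.0-fold higher number from compound 3 to compound 4 (0.01 log units; within the scatter). Compound 4 is expected at 1000 nM, within a range of 400 nM to 2500 nM.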

Compound 4, half-maximal inhibitory concentration: 1000 nM
Compound 4: the middle estimate sits on the measured number at the digits printed; the measured number falls inside the stated range.
By their numbers in this assay, from the lowest: compounds 1, 3 and 4 (each within the scatter of the next); then compound 2.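

In this assay, a phenyl ring at the end of the chain, with a hydrogen on the amine and one defined stereocentre, gives a number level with that of the cyclohexyl(methyl)amino group (a 1.0-fold higher number from compound 3 to compound 4 (0.01 log units; within the scatter)). Compound 4 also stands level with compound 1 (a 1.1-fold higher number from compound 1 to compound 4 (0.04 log units; within the scatter)), while compound 2 stays apart (a 7.6-fold lower number from compound 2 to compound 4 (0.88 log units; beyond the scatter)). No evidence available here accounts for these results. The compounds shown leave open whether the opposite stereoisomer of the 1-phenylethyl group or a pyridine ring in place of the phenyl ring would keep the number level.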